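The source may hold more compounds than are shown below. What is called first, only, known or untested is meant among the compounds shown, and "the series" means these compounds.

In a functional assay on NCI-H460 cells (Homo sapiens) for antiproliferative activity, read by XTT assay, with a stated time of 72 h (on this read-out higher numbers stand for weaker inhibition and lower numbers for stronger inhibition), compound 1 `COc1ccc(-c2cc3ccccc3nc2/C=C/C(=O)c2ccccc2)cc1` gives 6670 nM, compound 2 `COc1ccc(-c2cc3ccccc3nc2/C=C/C(=O)c2ccc(F)cc2)cc1` gives 6990 nM and compound 3 `COc1ccc(-c2cc3ccccc3nc2/C=C/C(=O)c2ccc(OC)cc2OC)cc1` gives 7040 nM. Compound 2 thus stands level with both others, as the step of a 1.0-fold higher number from compound 1 to compound 2 (0.02 log units; within the scatter) shows. Compound 4 `COc1ccc(-c2cc3ccccc3nc2/C=C/C(=O)c2ccco2)cc1` has furan-2-yl in place of 4-fluorophenyl on a carbonyl carbon. Two measured changes at that same place bear on it: a 1.1-fold higher number from compound 1 to compound 3 (0.02 log units; within the scatter) and a 1.0-fold higher number from compound 2 to compound 3 (0.00 log units; within the scatter). Both are small, but neither introduces furan-2-yl, so this evidence is indirect. No change beyond the scatter is therefore expected in this assay, in either direction. The estimated step is a 1.1-fold lower number from compound 2 to compound 4 (0.05 log units; within the scatter). For compound 4 the estimated value is 6300 nM, with an expected range of 2800 nM to 13000 nM.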

Compound 4, half-maximal inhibitory concentration: 6430 nM
Compound 4: middle estimate off by 1.0-fold (0.01 log units), on the low side; low and high end bracket the measured number.
By their numbers in this assay, from the lowest: compounds 4, 1, 2 and 3 (each within the scatter of the next).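

In this assay, within the data shown here, furan-2-yl puts a five-membered ring on the carbonyl carbon for the first time, with a hetero atom and a hydrogen-bond acceptor that 4-fluorophenyl lacks, yet the number stays within the scatter (a 1.1-fold lower number from compound 2 to compound 4 (0.04 log units; within the scatter)). The comparisons with the 2,4-dimethoxyphenyl and phenyl compounds also stay within the scatter (a 1.1-fold lower number from compound 3 to compound 4 (0.04 log units; within the scatter)) and (a 1.0-fold lower number from compound 1 to compound 4 (0.02 log units; within the scatter)). No measurement available here explains this flat result.

Every group shown at this place is an aromatic ring. Going by these compounds, whether an amine, a carboxylic acid or a longer chain on the carbonyl carbon would move the number remains open.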